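A few compounds are considered here, and "the series" means these few. Any claim that something is new, unique, unknown or untested is made for them only; others in the source may bear on it.

Measured compounds:
- compound 1 `COc1ccc(Cn2nc(-c3ccccc3)c3cc(C(=N)Nc4cccc(C(F)(F)F)c4)nc(NC4CCCCC4)c32)cc1` — "not determined" (no result reported)
- compound 2 `N=C(Nc1ccccc1)c1cc2c(-c3ccccc3)n[nH]c2c(NC2CCCCC2)n1` — 1730 nM

Among the compounds with values here, in a functional assay on PC-3 cells (Homo sapiens) for cytotoxicity, read by MTT assay, with a stated time of 72 h (a lower number here means a stronger inhibitor, a higher number a weaker inhibitor), compound 2 gives 1730 nM; this is the only number available, as compound 1 carries no result in this assay, so compound 2 cannot be ranked against anything. Compound 3 `N=C(Nc1cccc(C(F)(F)F)c1)c1cc2c(-c3ccccc3)n[nH]c2c(NC2CCCCC2)n1` is not yet measured. It differs from compound 2 in one place: trifluoromethyl in place of hydrogen on an aromatic carbon. Within the data shown here, no step between two measured compounds is available to calibrate such a change, so its size can only be guessed. A change of this kind is expected to move the value by a modest amount, most likely toward a stronger inhibitor, though a result within the usual scatter would not surprise. The step from compound 2 to compound 3 is thus expected to be a 1.7-fold lower number from compound 2 to compound 3 (0.24 log units; within the scatter). Compound 3 is estimated at 1000 nM in this assay, with a plausible range from 300 nM to 4000 nM.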

Compound 3, half-maximal inhibitory concentration: 25000 nM
Compound 3: the middle estimate sits 25-fold (1.40 log units) below what was measured; measured number above the stated range.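

In this assay the change from phenyl to 3-(trifluoromethyl)phenyl on the amidine nitrogen gives a 14-fold higher number from compound 2 to compound 3 (1.16 log units; beyond the scatter) and so shows that this aromatic carbon, meta to a large group, does not tolerate every substituent. Within the data shown here, the earlier compounds offered no step at all, and this is the first sign that one group on this ring can shift the cytotoxicity read-out beyond the usual scatter, here toward a weaker inhibitor. No measurement shown here explains the loss.

It remains open whether the loss is particular to trifluoromethyl, as fluorine, methyl or methoxy at this same carbon are not among the compounds shown. Also open, from the compounds shown here alone, is how an amine or a carboxylic acid on this ring would read, or trifluoromethyl on another of its carbons.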